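Hydroxy-chromenone series: aryl change from compound 2 to compound 3

The compounds below may be only part of what the source reports. "The series", "measured", "known", "first", "only" and "open" are said of these compounds alone.

Measured so far:
Compound 1, `CCC1=C(O)c2c(oc(-c3ccc(C(F)(F)F)cc3)cc2=O)C(CC)(CC)C1=O`: 35.7 uM
Compound 2, `CCC1=C(O)c2c(oc(-c3ccc(OC)cc3)cc2=O)C(CC)(CC)C1=O`: 17.7 uM

Going by the values given here, in a functional assay on KB cells (Homo sapiens) for antiproliferative activity, read by sulforhodamine B assay, with a stated time of 3 days (a higher number here means that more compound is needed for the effect, a lower number that less compound is needed), compound 2 and compound 1 are not separated beyond the scatter; the single measured step reads a 2.0-fold lower number from compound 1 to compound 2 (0.30 log units; within the scatter). Compound 3, `CCC1=C(O)c2c(oc(-c3cccc(F)c3)cc2=O)C(CC)(CC)C1=O`, is not yet measured. Its change from compound 2 is 3-fluorophenyl in place of 4-methoxyphenyl on an aromatic carbon. Among the compounds with values here, the only step that bears on it, the one from compound 1 to compound 2, stayed within the scatter, so no step beyond the scatter is expected for compound 3, in either direction. For compound 3 the estimate is 25 uM, within 10 uM to 60 uM. The expected step is a 1.4-fold higher number from compound 2 to compound 3 (0.15 log units; within the scatter).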

Compound 3, concentration for half-maximal effect: > 56.2 uM
Compound 3 ended at the assay's limit (the forecaster's own chance of this, stated with the estimate: 5%); middle value at least 2.2-fold (0.35 log units) from the limit.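

Replacing 4-methoxyphenyl with 3-fluorophenyl on this aromatic carbon next to the ring oxygen gives an at least 3.1-fold higher number from compound 2 to compound 3 (0.50 log units; beyond the scatter). Going by these compounds alone, this is the first step beyond the scatter, so the aryl group at this position can shift the read-out in this assay. Compound 3 stands at a limit of the assay, not at a number: the limit of > 56.2 uM in this assay, at which 1 of the 3 values shown sits.

From the compounds shown here alone, the true size of the step therefore stays open. Also open, going by these compounds, is whether it follows the fluorine or the substituent's place on the aryl ring, which 4-fluorophenyl or 3-methoxyphenyl would help to separate.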